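The source may report more compounds than this note shows. Statements on the series, on what has been measured and on what is new or still open speak of the compounds shown alone.

Working notes on the amide series in a functional assay on BGC-823 cells (Homo sapiens) for cytotoxicity, read by MTT assay, with a stated time of 72 h; a lower number here means a stronger inhibitor, a higher number a weaker inhibitor. The shared core carries an amide whose acyl group is the only point of variation. Compound 1 `COc1ccc(C(=O)NC[C@H]2c3[nH]c4ccccc4c3C[C@H]3[C@H]4c5[nH]c6ccccc6c5C[C@@H]([C@H](C#N)N23)N4C)cc1` gives 320 nM. Compound 2 `CN1[C@@H]2c3[nH]c4ccccc4c3C[C@H]1[C@H](C#N)N1[C@@H](CNC(=O)c3cccc4c3CCCC4)c3[nH]c4ccccc4c3C[C@@H]21` gives 3540 nM. Compound 3 `CN1[C@@H]2c3[nH]c4ccccc4c3C[C@H]1[C@H](C#N)N1[C@@H](CNC(=O)c3ccc4ccccc4n3)c3[nH]c4ccccc4c3C[C@@H]21` gives 80 nM. Compound 3 stands lowest of the three numbers: the step of a 4.0-fold lower number from compound 1 to compound 3 (0.60 log units; beyond the scatter) and the step of a 44-fold lower number from compound 2 to compound 3 (1.65 log units; beyond the scatter) both lie beyond the scatter, and the step of an 11-fold higher number from compound 1 to compound 2 (1.04 log units; beyond the scatter) shows how far the acyl group alone can move the number within this set.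

Compound 4 `COc1ccc(/C=C/C(=O)NC[C@H]2c3[nH]c4ccccc4c3C[C@H]3[C@H]4c5[nH]c6ccccc6c5C[C@@H]([C@H](C#N)N23)N4C)cc1` differs from compound 3 by 2-(4-methoxyphenyl)ethenyl in place of quinolin-2-yl on a carbonyl carbon. Going by the values given here, no measured step introduces a double bond outside the aromatic rings at this place; the nearest guide is a 4.0-fold lower number from compound 1 to compound 3 (0.60 log units; beyond the scatter), reused in reverse, as compound 4 carries the 4-methoxyphenyl of compound 1 extended by an ethenyl. The working assumption is a return toward the number of compound 1, with the ethenyl an untested variable that widens the range. The step from compound 3 to compound 4 is therefore expected to be a 3.8-fold higher number from compound 3 to compound 4 (0.57 log units; beyond the scatter). Compound 4 is expected at 300 nM, in the range 80 nM to 1200 nM.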

Compound 4, half-maximal inhibitory concentration: 5450 nM
For compound 4 the middle estimate is 18-fold (1.26 log units) below the measured one; the whole stated range lies below it.
By their numbers in this assay, from the lowest: compound 3; then compound 1; then compounds 2 and 4 (each within the scatter of the next).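

In this assay, going by these compounds alone, the ethenyl is the first change that keeps the 4-methoxyphenyl on the acyl side and alters only its attachment to the carbonyl carbon, and it brings a large loss: a 17-fold higher number from compound 1 to compound 4 (1.23 log units; beyond the scatter). Heavy-atom count does not track the number at this position, since quinolin-2-yl and 2-(4-methoxyphenyl)ethenyl have equal counts and equal hydrogen-bond acceptor counts, yet the exchange gives a 68-fold higher number from compound 3 to compound 4 (1.83 log units; beyond the scatter), the largest step in the set. The result also shows that two different acyl groups can end up level, with 2-(4-methoxyphenyl)ethenyl and 1,2,3,4-tetrahydronaphthalen-5-yl separated by only a 1.5-fold higher number from compound 2 to compound 4 (0.19 log units; within the scatter).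

Going by these compounds, it remains open whether the ethenyl would bring a similar loss with another aryl group, such as 2-(quinolin-2-yl)ethenyl, and whether a saturated 2-(4-methoxyphenyl)ethyl chain would behave like the ethenyl. No measurement to hand accounts for any of these steps.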